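Thiourea series: cytotoxicity notes ahead of compound 4

The source may report more compounds than this note shows. Statements on the series, on what has been measured and on what is new or still open speak of the compounds shown alone.

Three thioureas have numbers in an ADME assay on MT4 cells (Homo sapiens) for cytotoxicity; on this read-out lower numbers stand for higher toxicity in this test and higher numbers for lower toxicity in this test. Compound 1 `C=C(C)CNC(=S)Nc1cccc(C(F)(F)F)c1` gives 43000 nM. Compound 2 `CC[C@H]1CC[C@H](c2ccc(NC(=S)Nc3cccc(C(F)(F)F)c3)cc2)CC1` gives 39000 nM, the second highest of the three; compound 1 lies nearest and compound 3 furthest, both within the scatter. Compound 3 `Cc1ccc(NC(=S)Nc2cccc(C(F)(F)F)c2)cc1Cl` gives 20000 nM. Compound 4 `CCOC(=O)c1ccc(NC(=S)Nc2cccc(C(F)(F)F)c2)cc1` has no number yet in this assay. Its change from compound 2: ethoxycarbonyl in place of 4-ethylcyclohexyl on an aromatic carbon. Among the measured compounds shown here, no step between two measured compounds that differ in one place is available, so the size of this step rests on the spread of the three numbers alone. Since all three sit within the scatter of one another, no step beyond the scatter is expected in this assay, in either direction. Compound 4 is expected at 35000 nM, within 15000 nM to 80000 nM. This estimate means an expected step of a 1.1-fold lower number from compound 2 to compound 4 (0.05 log units; within the scatter).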

Compound 4, half-maximal cytotoxic concentration: 23000 nM
For compound 4 the middle estimate is 1.5-fold (0.18 log units) above the measured one; the measured number falls inside the stated range.
By their numbers in this assay, from the lowest: compounds 3, 4, 2 and 1 (each within the scatter of the next, the first and the last beyond it).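

Ethoxycarbonyl in place of 4-ethylcyclohexyl gives the first one-place step of the series in this assay, with a 1.7-fold lower number from compound 2 to compound 4 (0.23 log units; within the scatter) as its size. At this aromatic carbon, para to a large group, a carbon-only ring substituent and an open one carrying hydrogen-bond acceptors therefore give numbers that cannot be separated in this test. From the compounds shown here alone, whether a carboxylic acid, an amine or a longer alkyl chain on the same carbon would stay within the scatter remains open. No measurement at hand explains this result.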